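Moving the methoxy group and methylating the amide nitrogen

A few compounds are considered here, and "the series" means these few. Any claim that something is new, unique, unknown or untested is made for them only; others in the source may bear on it.

Compound 1 `COc1ccc(-c2cccc(C(=O)N(C)C)c2)cc1S(=O)(=O)Nc1ccc2ccc(NC(=O)c3ccccc3)cc2c1`, compound 2 `COc1ccc(-c2cccc(C(=O)N(C)C)c2)cc1S(=O)(=O)Nc1ccc2cccc(NC(=O)c3ccccc3)c2c1` and compound 3 `COc1cccc(C(=O)Nc2cccc3ccc(NS(=O)(=O)c4cc(-c5cccc(C(=O)N(C)C)c5)ccc4OC)cc23)c1` share one core and differ only in the benzamide part. In a functional assay on CHO cells for agonist activity at Orexin/Hypocretin receptor type 1 (Homo sapiens) (a lower number here means that less compound is needed, a higher number that more compound is needed for the effect), compound 1 reaches only a limit, > 10000 nM. Compound 2 also stops at a limit, > 10000 nM, in this assay. Compound 3 gives 473 nM and is thus the only one of the three with a measured number. From the compounds shown here alone, the step of an at least 21-fold lower number from compound 2 to compound 3 (1.32 log units; beyond the scatter) is large, and its true size stays open because of the limit of > 10000 nM in this assay, at which 2 of the 3 values shown sit.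

Compound 4 `COc1ccccc1C(=O)N(C)c1cccc2ccc(NS(=O)(=O)c3cc(-c4cccc(C(=O)N(C)C)c4)ccc3OC)cc12` is not yet measured. It differs from compound 3 in one place: ((2-methoxyphenyl)carbonyl)(methyl)amino in place of ((3-methoxyphenyl)carbonyl)amino on an aromatic carbon. The methoxy group changes its place on the benzoyl ring and the amide nitrogen carries a methyl in place of its hydrogen. For the measured compounds named here, the only measured step, the gain from compound 2 to compound 3, concerns adding a methoxy group, not moving it or methylating the nitrogen, so it bears on compound 4 only loosely. With no closer guide, compound 4 is expected to give 1500 nM in this assay, within 300 nM to 8000 nM. That estimate amounts to a step of a 3.2-fold higher number from compound 3 to compound 4 (0.50 log units; beyond the scatter), a moderate loss with a fair chance that only a limit is reported.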

Compound 4, half-maximal effective concentration: > 10000 nM
Compound 4: no number, only a limit; the forecaster's own chance of this, stated with the estimate: 30%; middle value at least 6.6-fold (0.82 log units) from the limit.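

In this assay a methoxy group on the benzoyl ring is not enough on its own to give a measurable effect: compound 4 still carries one, yet ((2-methoxyphenyl)carbonyl)(methyl)amino in place of ((3-methoxyphenyl)carbonyl)amino gives an at least 21-fold higher number from compound 3 to compound 4 (1.32 log units; beyond the scatter). The value of compound 4, > 10000 nM, is a limit, and the step from compound 2 to compound 4 cannot be read, with a limit at each end. From the compounds shown here alone, the true size of the loss from compound 3 stays open because of where the values in this set sit: the limit of > 10000 nM in this assay, at which 3 of the 4 values shown sit.

The single change combines two differences, the new place of the methoxy group and the methyl that replaces the amide hydrogen, so the compounds shown cannot tell which of them matters, or whether both do; ((2-methoxyphenyl)carbonyl)amino, which would separate them, is not among them. Also open, going by these compounds, is whether anything other than methoxy on the benzoyl ring, such as a hydroxy group, a chlorine or an ethoxy group, would lower the number further than compound 3 does.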